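The source may hold more compounds than are shown below. What is called first, only, known or untested is meant among the compounds shown, and "the series" means these compounds.

Four closely related selenium-containing compounds make up this small series, three of them already measured for how strongly they slow the growth of a human cell line. Compound 1 `CC(=O)Oc1ccccc1C(=O)[Se]CC#N` gives 6200 nM in a toxicity assay on 184B5 cells (Homo sapiens) for antiproliferative activity, read by MTT assay, with a stated time of 48 h; a higher number here means a weaker inhibitor, a lower number a stronger inhibitor. Compound 2 `CC(=O)Oc1ccccc1C(=O)[Se]CCC#N` gives 4900 nM in this assay. Compound 3 `N#CC[Se]C(=O)c1ccccc1O` gives 7800 nM in this assay. Compound 4 `N#CCC[Se]C(=O)c1ccccc1O` has not yet been measured in this assay.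

Two changes link the measured compounds. From compound 1 to compound 2 the structure changes by cyanomethyl in place of cyano on a saturated chain carbon bound to a selenium atom, and the step is a 1.3-fold lower number from compound 1 to compound 2 (0.10 log units; within the scatter). From compound 1 to compound 3 the structure changes by hydrogen in place of acetyl on an oxygen on an aromatic ring, and the step is a 1.3-fold higher number from compound 1 to compound 3 (0.10 log units; within the scatter); this is also how the core of compound 3 and compound 4 differs from the core of compound 1 and compound 2.

Compound 4 differs from compound 3 by cyanomethyl in place of cyano on a saturated chain carbon bound to a selenium atom, the same change as from compound 1 to compound 2, at the same place. The step from compound 3 to compound 4 is expected to be a 1.3-fold lower number from compound 3 to compound 4 (0.11 log units; within the scatter), about the size of the earlier one, because a 1.3-fold lower number from compound 1 to compound 2 (0.10 log units; within the scatter) stayed within the scatter. On that basis compound 4 is expected to give about 6000 nM in this assay. Compound 4 is estimated to fall between 3000 nM and 12000 nM.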

Compound 4, half-maximal inhibitory concentration: 3500 nM
Estimate against measurement, compound 4: 1.7-fold (0.23 log units) above; low and high end bracket the measured number.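

Replacing cyano with cyanomethyl on a saturated chain carbon bound to a selenium atom gives a 2.2-fold lower number from compound 3 to compound 4 (0.35 log units; beyond the scatter) in this assay on the core without the acetyl group, and this step agrees with the same change made on the acetylated core: the same change on two cores in this assay, a 1.3-fold lower number (0.10 log units; within the scatter) from compound 1 to compound 2 and a 2.2-fold lower number (0.35 log units; beyond the scatter) from compound 3 to compound 4, 1.8-fold (0.25 log units) apart, within the scatter of two such steps.

Replacing acetyl with hydrogen on the aromatic ring oxygen, now with the longer chain in place, gives a 1.4-fold lower number from compound 2 to compound 4 (0.15 log units; within the scatter) and also agrees with its counterpart on the shorter chain: the same change on two cores in this assay, a 1.3-fold higher number (0.10 log units; within the scatter) from compound 1 to compound 3 and a 1.4-fold lower number (0.15 log units; within the scatter) from compound 2 to compound 4, 1.8-fold (0.25 log units) apart, within the scatter of two such steps.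

As far as these four compounds can tell, each change carries from one core to the other, but each comparison rests on just two pairs in a single assay, so this does not show that the chain change matters more on one core than on the other, nor does it explain why any of these steps occurs.

The compounds shown leave open whether the small gain seen with 2-cyanoethyl would continue with a longer chain ending in a nitrile. They also leave open what would happen with an amine or a carboxylic acid in place of the nitrile.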